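Aryl swap at the nitrile-flanked ring carbon of the core

A few compounds are considered here, and "the series" means these few. Any claim that something is new, unique, unknown or untested is made for them only; others in the source may bear on it.

Compound 1 `COc1cc(-c2c(C#N)c(-c3ccco3)nc3c2c(-c2ccccc2)nn3-c2ccccc2)ccc1O` carries furan-2-yl on the shared core; in a functional assay on MV4-11 cells (Homo sapiens) for antiproliferative activity, read by resazurin assay, with a stated time of 72 h (on this read-out lower numbers stand for stronger inhibition and higher numbers for weaker inhibition), compound 1 gives 35300 nM. Compound 2 `COc1cc(-c2c(C#N)c(-c3cccs3)nc3c2c(-c2ccccc2)nn3-c2ccccc2)ccc1O` carries thiophen-2-yl at the same carbon; in this assay compound 2 gives 44200 nM. Among the compounds with values here, the one measured step, a 1.3-fold higher number from compound 1 to compound 2 (0.10 log units; within the scatter), is a five-membered heteroaryl exchange and stays within the scatter. Compound 2 holds the highest number of the two, with compound 1 nearest, a gap that is itself within the scatter. Compound 3 `COc1cc(-c2c(C#N)c(-c3ccccc3)nc3c2c(-c2ccccc2)nn3-c2ccccc2)ccc1O` is the next member: phenyl in place of thiophen-2-yl on an aromatic carbon. Within the data shown here, the only comparison that bears on this change is the heteroaryl swap a 1.3-fold higher number from compound 1 to compound 2 (0.10 log units; within the scatter), which was flat; no step involving a six-membered carbocycle at this position has been measured. The step of a 1.1-fold lower number from compound 2 to compound 3 (0.02 log units; within the scatter) from compound 2 to compound 3 in this assay is therefore expected to stay within the scatter. Compound 3 is estimated at 42000 nM in this assay, with a range from 15000 nM to 120000 nM.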

Compound 3, half-maximal inhibitory concentration: > 50000 nM
Compound 3 was reported as a limit; the forecaster's own chance of this, stated with the estimate: 25%; middle value at least 1.1-fold (0.07 log units) away from the limit.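

Compound 3 is the first member with a six-membered carbocycle at this carbon, and in this assay its reading is a limit, not a number: the limit of > 50000 nM in this assay, at which 1 of the 3 values shown sits.

Both new steps rest on that limit, an at least 1.1-fold higher number from compound 2 to compound 3 (0.05 log units; that floor lies within the scatter) and an at least 1.4-fold higher number from compound 1 to compound 3 (0.15 log units; that floor lies within the scatter), and neither floor lies beyond the scatter, while their true size cannot be read. Across furan-2-yl, thiophen-2-yl and phenyl at this position, no printed step therefore goes beyond the scatter, and phenyl shows no sign of stronger inhibition.

Still open, from the compounds shown here alone, is whether a non-aromatic group at this carbon, such as an amine or a carboxylic acid, would give a clearly different number. Going by these compounds, the 4-hydroxy-3-methoxyphenyl group and the cyano group are shared by all three compounds, so what each contributes remains unknown.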